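The source may hold more compounds than are shown below. What is called first, only, known or untested is meant among the compounds shown, and "the series" means these compounds.

Working notes on the series, read in a functional assay on MV4-11 cells (Homo sapiens) for inhibition, read by resazurin assay, with a stated time of 72 h; on this read-out lower numbers stand for stronger inhibition of growth and higher numbers for weaker inhibition of growth. Compound 1 (`COc1ccc(Nc2nccc(-c3sc(SCCCN(C)C)nc3C)n2)c(OC)c1`) gives 370 nM and compound 2 (`CCSc1nc(C)c(-c2ccnc(Nc3ccc(OC)cc3OC)n2)s1`) gives 32400 nM, so compound 2 holds the higher of the two numbers. The next structure is compound 3 (`CCCCOc1nc(C)c(-c2ccnc(Nc3ccc(OC)cc3OC)n2)s1`), not yet measured. Its change from compound 2 is butoxy in place of ethylsulfanyl on an aromatic carbon, next to the ring nitrogen and next to the ring sulfur. For the measured compounds named here, only one measured step bears on this, and only indirectly: an 88-fold higher number from compound 1 to compound 2 (1.94 log units; beyond the scatter), with hydrogen in place of (dimethylamino)methyl on a saturated chain carbon. Going by the values given here, that step is large and beyond the scatter, but it concerns a different group, and no measured pair compares butoxy with ethylsulfanyl. Compound 3, like compound 2, carries no dimethylamino group, so a return to the level of compound 1 at 370 nM is not expected. A small move towards a lower number is expected, perhaps none beyond the scatter. The expected step is a 1.6-fold lower number from compound 2 to compound 3 (0.21 log units; within the scatter). For compound 3 the estimated value is 20000 nM, with an expected range of 6000 nM to 60000 nM.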

Compound 3, concentration for 50% growth inhibition: 7860 nM
Beside the measured number, compound 3's estimate is 2.5-fold (0.41 log units) above it; the measured number falls inside the stated range.
By their numbers in this assay, from the lowest: compound 1; then compound 3; then compound 2.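

In this assay, the position on the aromatic carbon next to the ring nitrogen and next to the ring sulfur responds to a change even without a dimethylamino group: butoxy in place of ethylsulfanyl gives a 4.1-fold lower number from compound 2 to compound 3 (0.62 log units; beyond the scatter), a modest step beyond the scatter. Butoxy still does not match (3-(dimethylamino)propyl)sulfanyl at this position, with a 21-fold higher number from compound 1 to compound 3 (1.33 log units; beyond the scatter), so the step gained from ethylsulfanyl recovers only part of the gap, and compound 1 remains the lowest of the three. Nothing measured on these compounds accounts for either step.

The butoxy change replaces the sulfur link with an oxygen link and alters the chain in the same step, so the compounds shown cannot say which of the two carries the effect; butylsulfanyl or ethoxy at this position would separate them. Also open, as far as these compounds go, is whether the dimethylamino end keeps its effect on an oxygen-linked chain, as in 3-(dimethylamino)propoxy, and whether another terminal group, such as a carboxylic acid, would do the same on that chain.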